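The source may hold more compounds than are shown below. What is called first, only, known or untested is meant among the compounds shown, and "the series" means these compounds.

Compound 1: `Cc1cccc(Oc2ccnc(N3CCC[C@H]3C(=O)NCc3cccnc3)n2)c1` gives 0% in an assay on isolated protein for inhibition of vascular endothelial growth factor receptor 1 (Homo sapiens), read by HTRF, tested at 10 uM; a higher number here means more inhibition at the concentration tested (going by the name of the read-out), a lower number less inhibition.
Compound 2: `Cc1cccc(Oc2ccnc(N3CCN(C(=O)c4c(C)noc4C)CC3)n2)c1` gives 7% in this assay.

Compound 1 gives the smaller of the two numbers, but the gap to compound 2 lies within the usual scatter of repeated measurements, so the two cannot be told apart on these data. Both sit at the bottom of the scale.

Compound 3, `COC(=O)C(CO)NC(=O)[C@@H]1CCCN1c1nccc(Oc2cccc(C)c2)n1`, has not been measured yet. It differs from compound 1 in one place: 2-hydroxy-1-(methoxycarbonyl)ethyl in place of (pyridin-3-yl)methyl on an amide-type nitrogen. Among the compounds with values here, no step between measured compounds touches this position, so nothing here shows whether this part of the molecule matters. Because compound 1 gives 0% and there is little room to fall further, compound 3 is expected to stay close by, with a step of a number 4 percentage points higher from compound 1 to compound 3 (within the scatter) that is not expected to reach beyond the scatter. The estimate for compound 3 is 4%, within a range of 0% to 16%.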

Compound 3, a percentage reported as inhibition, at one concentration (the size of the read-out at that concentration, not a potency): 0%
For compound 3 the middle estimate is 4 percentage points above the measured one; measured number inside the range.
By their numbers in this assay, from the lowest: compounds 1, 3 and 2 (each within the scatter of the next).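

In this assay the swap of (pyridin-3-yl)methyl for 2-hydroxy-1-(methoxycarbonyl)ethyl on the amide-type nitrogen gives no change at the digits printed from compound 1 to compound 3 (within the scatter) and so brings no gain in inhibition. The new group has no ring and adds a hydrogen-bond donor, yet neither difference lifts the number off the bottom of the scale, although a drop could hardly show up from such a low start. Nothing available explains this result.

From the compounds shown here alone, whether any group on this nitrogen can raise the number stays open, for example a carboxylic acid in place of the methoxycarbonyl, or a longer chain ending in an amine. It is also unclear whether this position would matter in a compound that starts from clear inhibition, where a loss could be seen.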